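Replacing a nitrophenyl ether with a naphthyl ether

The source may report more compounds than this note shows. Statements on the series, on what has been measured and on what is new or still open speak of the compounds shown alone.

The three measured compounds share one core and differ in the aryl group carried on the ether oxygen. Compound 1 `CCCc1nc2ccccc2c(=O)n1/N=C/c1ccc(Oc2ccc(Cl)c(C)c2)cc1` gives 6.02 in a physicochemical assay for lipophilicity, in phosphate buffer, measured as octanol-water partition; a lower number here means a more polar compound, a higher number a more lipophilic compound. Compound 2 `CCCc1nc2ccccc2c(=O)n1/N=C/c1ccc(Oc2ccc(F)cc2)cc1` gives 5.22; the step of a number 0.80 log units lower from compound 1 to compound 2 (beyond the scatter) shows how far a smaller halogenated aryl group on that oxygen lowers this assay. Compound 3 `O=c1c2ccccc2nc(-c2ccccc2)n1/N=C/c1ccc(Oc2ccc([N+](=O)[O-])cc2)cc1`, which carries a phenyl group on its core and a nitro-bearing aryl ether, gives 6.12. Among the three numbers compound 3 is highest, within the scatter of compound 1 and beyond the scatter of compound 2.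

Compound 4 `O=c1c2ccccc2nc(-c2ccccc2)n1/N=C/c1ccc(Oc2ccc3ccccc3c2)cc1` is not yet measured. The change is naphthalen-2-yl in place of 4-nitrophenyl on an oxygen on an aromatic ring. Going by the values given here, no measured step replaces this particular group, so only the direction can be borrowed: the sole measured step, from compound 1 to compound 2, moved a modest distance when the aryl group shrank, and here the aryl group grows while two hydrogen-bond acceptors leave. Compound 4 is therefore expected to rise beyond the scatter, by about a number 0.98 log units higher from compound 3 to compound 4 (beyond the scatter), giving an estimated 7.1 with a range from 6.4 to 7.8.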

Compound 4, partition coefficient: 6.53
Beside the measured number, compound 4's estimate is 0.57 log units above it; low and high end bracket the measured number.
By their numbers in this assay, from the lowest: compound 2; then compounds 1 and 3 (each within the scatter of the next); then compound 4.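

In this assay, putting naphthalen-2-yl in place of 4-nitrophenyl on an oxygen on an aromatic ring gives a number 0.41 log units higher from compound 3 to compound 4 (beyond the scatter), so the read-out responds to a change at this position on the core of compound 3, and not only on the core of compound 1. Set against a number 0.80 log units lower from compound 1 to compound 2 (beyond the scatter), this is a second modest step at the same position, but the cores and the exchanged groups both differ, so the two steps do not form a single trend. This change removes a nitro group and adds a second aromatic ring in one exchange, and nothing available here accounts for the size of the step.

The compounds shown leave open how much of the step belongs to the loss of the nitro group and how much to the added ring, a question that plain phenyl on the same oxygen of the core of compound 3 would address. They also leave open how this assay would read with an amine or a carboxylic acid on that aryl group.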